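Cytotoxicity of a thiocarbamate series: a naphthyl replaces methylphenyl

This account rests on a few compounds, and the source may have more. Where it says the series, first, only, none or still open, it means among the compounds named here.

Compound 1 `Cc1cccc(C(=O)N(C(=S)OCCN2C(=O)c3ccccc3C2=O)c2ccc(Cl)cc2)c1`: 58000 nM
Compound 2 `Cc1ccc(N(C(=O)c2cccc(C)c2)C(=S)OCCN2C(=O)c3ccccc3C2=O)cc1`: > 100000 nM, a limit of the assay
Compound 3 `O=C1c2ccccc2C(=O)N1CCOC(=S)N(C(=O)c1ccc(Cl)c([N+](=O)[O-])c1)c1ccccc1`: 51000 nM

Going by the values given here, in an ADME assay on MT4 cells (Homo sapiens) for cytotoxicity, read by MTT assay (a lower number here means that less compound is tolerated, a higher number that more compound is tolerated), compound 1 gives 58000 nM, the higher of the two plain numbers measured so far. Compound 3 gives 51000 nM, and the gap between the two is within the usual scatter, so they cannot be ranked. Compound 2 gives only a limit of > 100000 nM. Going an at least 1.7-fold higher number from compound 1 to compound 2 (0.23 log units; that floor lies within the scatter) the number rises, but since it ends at a limit, (the limit of > 100000 nM in this assay, at which 1 of the 3 values shown sits), only a floor on the step is known, and that floor itself sits within the scatter.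

Compound 4 `O=C1c2ccccc2C(=O)N1CCOC(=S)N(C(=O)c1ccc2ccccc2c1)c1ccc(Cl)cc1` differs from compound 1 by naphthalen-2-yl in place of 3-methylphenyl on a carbonyl carbon. Among the compounds with values here, the one step measured so far changes a group on an aromatic ring elsewhere in the molecule and says nothing about this carbonyl substituent, so no measured step bears on the present change. With nothing pointing up or down, the step is expected to stay within the scatter. Compound 4 is therefore expected to give about 55000 nM in this assay, within a range from 22000 nM to 100000 nM, which means an expected step of a 1.1-fold lower number from compound 1 to compound 4 (0.02 log units; within the scatter).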

Compound 4, half-maximal cytotoxic concentration: 37000 nM
The estimate for compound 4 lay 1.5-fold (0.17 log units) above the measured number; the range from low to high includes it.
By their numbers in this assay, from the lowest: compounds 4, 3 and 1 (each within the scatter of the next). At a limit, above all of these: compound 2.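

Going by these compounds alone, this pair gives the first reading at the carbonyl carbon whose other neighbour is the amide-type nitrogen. In this assay, exchanging 3-methylphenyl for naphthalen-2-yl, which brings a second six-membered aromatic ring of carbon only, gives a 1.6-fold lower number from compound 1 to compound 4 (0.20 log units; within the scatter). For this one pair, then, the added ring produces no change that can be told apart from the ordinary spread of repeated measurements, and nothing measured here offers an explanation for the numbers at this position.

A single pair with only carbon-based aromatic groups cannot show whether the position would stay this quiet with a different kind of group on the carbonyl carbon, such as a carboxylic acid, an amine or a saturated cyclohexyl ring. It also leaves open whether naphthalen-2-yl would read the same with methyl in place of chloro on the other aromatic ring, the change that separates compound 1 from compound 2.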